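This account rests on a few compounds, and the source may have more. Where it says the series, first, only, none or still open, it means among the compounds named here.

Measured compounds:
compound 1, `COc1cc2c(Oc3ccc(NC(=O)c4nn(-c5ccccc5C(F)(F)F)c(=O)cc4C)cc3F)ccnc2cc1OCCCN1CCCC1`: 140 nM
compound 2, `COc1cc2c(Oc3ccc(NC(=O)c4nn(-c5ccccc5OC(F)(F)F)c(=O)cc4C)cc3F)ccnc2cc1OCCCN1CCCC1`: 180 nM
compound 3, `COc1cc2c(Oc3ccc(NC(=O)c4nn(-c5ccccc5OC(F)(F)F)c(=O)cc4C)cc3F)ccnc2cc1OCCCN1CCN(C)CC1`: 180 nM

These three numbers come from a functional assay on HT-29 cells (Homo sapiens) for inhibition, read by MTT assay, with a stated time of 72 h; a lower number here means a stronger inhibitor, a higher number a weaker inhibitor. Compound 2 stands level with compound 3, the two together giving the highest of the three numbers, and compound 1 is the furthest of the three, yet the gap a 1.3-fold higher number from compound 1 to compound 2 (0.11 log units; within the scatter) is within the scatter. Compound 2 and compound 3 differ only in the group at the end of the chain, and that step, no change at the digits printed from compound 2 to compound 3 (within the scatter), shows no change either. Compound 4, `COc1cc2c(Oc3ccc(NC(=O)c4nn(-c5ccc(Cl)cc5)c(=O)cc4C)cc3F)ccnc2cc1OCCCN1CCCC1`, is not yet measured in this assay. It differs from compound 2 in one place: 4-chlorophenyl in place of 2-(trifluoromethoxy)phenyl on an aromatic nitrogen. For the measured compounds named here, only the step from compound 1 to compound 2 touches this part of the molecule; it swapped one small group for another on that ring while the ring itself stayed, and its size, a 1.3-fold higher number from compound 1 to compound 2 (0.11 log units; within the scatter), was within the scatter. Going by the values given here, the present change replaces the whole substituted ring, so no measured step tells its direction. The expectation for compound 4 is therefore a number near compound 2, a step of a 1.1-fold lower number from compound 2 to compound 4 (0.05 log units; within the scatter), with a wider range than usual. Compound 4 is estimated at 160 nM, between 60 nM and 450 nM.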

Compound 4, half-maximal inhibitory concentration: 260 nM
The estimate for compound 4 lay 1.6-fold (0.21 log units) below the measured number; measured number inside the range.
By their numbers in this assay, from the lowest: compounds 1, 2, 3 and 4 (each within the scatter of the next).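

In this assay, for the compounds shown here, the earlier compounds changed only a small group on the ring attached to the aromatic nitrogen, whereas compound 4 replaces the whole substituted ring, and the outcome is a 1.4-fold higher number from compound 2 to compound 4 (0.16 log units; within the scatter) and a 1.9-fold higher number from compound 1 to compound 4 (0.27 log units; within the scatter). So a ring with a chlorine in the 4-position, 7 heavy atoms in all, reads the same within the scatter as the 2-substituted rings with their larger groups, and this position accepts a change of both the group and its place on the ring without a clear shift in the number.

Going by these compounds, these steps change group and place together, so 2-chlorophenyl and 4-(trifluoromethoxy)phenyl would be needed to tell the two apart, and a saturated ring such as cyclohexyl or a phenyl ring carrying an amine or a carboxylic acid remains open. Nothing shown here explains why these steps stay so small.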